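Chain Lengthening on Two Cores in an Antiproliferative Series

This account rests on a few compounds, and the source may have more. Where it says the series, first, only, none or still open, it means among the compounds named here.

The series begins with compound 1 `CCCCCCCCC(CCO)n1cnc2c(N)nc(Cl)nc21`, which in a functional assay on HCT-116 cells (Homo sapiens) for antiproliferative activity, read by MTT assay, with a stated time of 48 h (a lower number here means a stronger inhibitor, a higher number a weaker inhibitor), gives 21000 nM. Compound 2 `CCCCCCCCCC(CCO)n1cnc2c(N)nc(Cl)nc21` carries one more carbon on the chain, a change counted as methyl in place of hydrogen on a saturated chain carbon, nine bonds along the chain from an aromatic nitrogen, and in this assay compound 2 gives 14800 nM; the step of a 1.4-fold lower number from compound 1 to compound 2 (0.15 log units; within the scatter) is small and stays inside the usual scatter.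

Compound 3 `CCCCCCCCCCCC(CCO)n1cnc2c(Cl)ncnc21` rests on a different core; the difference between the two cores is not broken down here. In this assay, among the compounds with values here, compound 3 gives 7590 nM, the lowest of the three numbers so far. Its gap to compound 2 lies within the scatter, while its gap to compound 1 lies beyond it.

Compound 4 `CCCCCCCCCCCCC(CCO)n1cnc2c(Cl)ncnc21` repeats on the core of compound 3 the same kind of change seen between compound 1 and compound 2: methyl in place of hydrogen on a saturated chain carbon, ten or more bonds along the chain from an aromatic nitrogen. The place is not the same word for word, since the distance of the carbon along the chain from an aromatic nitrogen is given separately for each pair in its own counted difference.

Compound 4 is therefore expected to give 5800 nM in this assay, with a range from 3000 nM to 11000 nM. For compound 4 this estimate means a step of a 1.3-fold lower number from compound 3 to compound 4 (0.12 log units; within the scatter). The expectation rests on the earlier step of a 1.4-fold lower number from compound 1 to compound 2 (0.15 log units; within the scatter), which barely moved the number, so only a modest shift is anticipated and not a move beyond the scatter.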

Compound 4, half-maximal inhibitory concentration: > 50000 nM
Compound 4 ended at the assay's limit (the forecaster's own chance of this, stated with the estimate: 5%); at least 8.6-fold (0.93 log units) between middle value and limit.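

Carrying methyl in place of hydrogen from the core of compound 1 to the core of compound 3 did not carry its result along, and the two steps differ: the same change on two cores in this assay, a 1.4-fold lower number (0.15 log units; within the scatter) from compound 1 to compound 2 and an at least 6.5-fold higher number (0.81 log units; beyond the scatter) from compound 3 to compound 4, at least 9.3-fold (0.97 log units) apart, beyond the scatter of two such steps

On the core of compound 3, the change gives an at least 6.5-fold higher number from compound 3 to compound 4 (0.81 log units; beyond the scatter) in this assay, and the full size of this step stays unknown, as compound 4 ended at a limit of the assay and not at a number: the limit of > 50000 nM in this assay, at which 1 of the 4 values shown sits.

Within the data shown here, the two pairs differ in chain length as well as in core, and there is only one pair on each core, so the result does not show whether the core, the chain length or both set the difference, and it gives no general rule for this change.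

The compounds shown leave open whether a longer chain on the core of compound 1 would also end at the limit, or whether that core would keep its small steps as the chain grows. They also leave open whether a shorter chain on the core of compound 3 would give a similar step, and whether an amine or a carboxylic acid at the chain end would alter the picture on either core.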